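Aryl piperazine variation in the T-type calcium channel series

This account rests on a few compounds, and the source may have more. Where it says the series, first, only, none or still open, it means among the compounds named here.

Measured compounds:
compound 1 `CCCc1nc(-c2ccccc2)c(CNCCN2CCN(c3ccc(Cl)cc3)CC2)o1` — 55.8%
compound 2 `CCCc1nc(-c2ccccc2)c(CNCCN2CCN(c3cccc(C(F)(F)F)c3)CC2)o1` — 56.3%
compound 3 `CCCc1nc(-c2ccccc2)c(CNCCCN2CCN(c3ccc(OC)cc3)CC2)o1` — 42.1%

In an assay on HEK293 cells for inhibition of Voltage-dependent T-type calcium channel subunit alpha-1G (Homo sapiens), read by fluorescence, tested at 10 uM (on this read-out lower numbers stand for less inhibition and higher numbers for more inhibition at the one concentration tested (going by the name of the read-out)), compound 3 stands lowest of the three; compound 1 lies beyond the scatter above it, and compound 2 likewise. Among the compounds with values here, the one measured step, a number 0.5 percentage points higher from compound 1 to compound 2 (within the scatter), concerns a different exchange and lies within the scatter, so it says little about the change at hand. Compound 4 `CCCc1nc(-c2ccccc2)c(CNCCCN2CCN(c3ccc(Cl)cc3)CC2)o1` carries chloro in place of methoxy on an aromatic carbon. Within the data shown here, the 4-chlorophenyl of compound 4 is also that of compound 1, which gives 55.8%, whereas compound 3 with 4-methoxyphenyl gives 42.1%; no measured step isolates this exchange. A modest rise is therefore expected, a number 7.9 percentage points higher from compound 3 to compound 4 (within the scatter). For compound 4 the estimate in this assay is 50%, within 36% to 64%.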

Compound 4, a percentage reported as inhibition, at one concentration (the size of the read-out at that concentration, not a potency): 63.3%
Beside the measured number, compound 4's estimate is 13.3 percentage points below it; low and high end bracket the measured number.
By their numbers in this assay, from the lowest: compound 3; then compounds 1, 2 and 4 (each within the scatter of the next).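

In this assay, the exchange on an aromatic carbon para to a large group gives a number 21.2 percentage points higher from compound 3 to compound 4 (beyond the scatter). Within the data shown here, this is the first measured step that isolates 4-methoxyphenyl to 4-chlorophenyl, and it shows that this single change, with the rest of the structure held constant, moves the read-out beyond the scatter. Nothing available accounts for the size of this step. Going by these compounds, how fluoro, nitrile or an amine would read at this position remains open, as does whether the same exchange gives a comparable step with a longer chain.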